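Cyclic sulfone acylguanidines: methoxy replacing isopropyl at the ring carbon

This account rests on a few compounds, and the source may have more. Where it says the series, first, only, none or still open, it means among the compounds named here.

Measured so far in an assay on cells for inhibition of sodium/hydrogen exchanger (Oryctolagus cuniculus); a higher number here means a weaker inhibitor, a lower number a stronger inhibitor:
Compound 1 `C=C1CCS(=O)(=O)c2cc(C(=O)N=C(N)N)c(C)cc21` gives 29 nM.
Compound 2 `Cc1cc2c(cc1C(=O)N=C(N)N)S(=O)(=O)CC2C(C)C` gives 21 nM.

Among the compounds with values here, only two numbers stand in this assay so far. Compound 2 sits at one end of the pair and compound 1 at the other, the gap between them lying within the usual scatter; the two values show no separation that can be read as a real difference. Within the data shown here, no step between measured compounds that differ in a single place is available, so the effect of changing the group on the saturated ring carbon is not yet pinned down.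

Compound 3 `COC1CS(=O)(=O)c2cc(C(=O)N=C(N)N)c(C)cc21` differs from compound 2 as follows: methoxy in place of isopropyl on a saturated ring carbon. Since compound 1 and compound 2 carry quite different groups at the same position and still fall together, the position appears tolerant over the two examples in hand, and a step of modest size, if any, is expected in this assay, with a slight lean toward a higher number.

The step of a 1.9-fold higher number from compound 2 to compound 3 (0.28 log units; within the scatter) is expected to stay small. Compound 3 is estimated at 40 nM, with a range from 12 nM to 150 nM.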

Compound 3, half-maximal inhibitory concentration: 96 nM
Beside the measured number, compound 3's estimate is 2.4-fold (0.38 log units) below it; measured number inside the range.
By their numbers in this assay, from the lowest: compounds 2 and 1 (each within the scatter of the next); then compound 3.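

In this assay, the change of isopropyl to methoxy on the saturated ring carbon gives a 4.6-fold higher number from compound 2 to compound 3 (0.66 log units; beyond the scatter), a modest step but one beyond the scatter. Within the data shown here, this is the only single-place step so far, and it shows that this carbon, two ring bonds from the ring sulfur, is not indifferent to the group it carries: the methoxy compound is the weaker inhibitor of the pair. Nothing on hand offers a reason for the step.

Going by these compounds, whether the higher number goes with the oxygen entering at this carbon or with the branched carbon group leaving it stays open; an ethyl group at the same carbon, made of carbon only, would help to separate the two readings. A hydroxyl group or an amine on this carbon would show whether the step seen with methoxy extends to other groups carrying a heteroatom, and a longer ether chain would show whether the number keeps moving as the oxygen-linked group grows.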